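Chloro in Place of Fluoro: Expecting a Small Shift

A few compounds are considered here, and "the series" means these few. Any claim that something is new, unique, unknown or untested is made for them only; others in the source may bear on it.

Compound 1 `CS(=O)(=O)c1ccc(F)cc1NCC1=NCCN1`: < 6310 nM
Compound 2 `CSc1ccc(F)cc1NCC1=NCCN1`: 331 nM
Compound 3 `CC(C)S(=O)(=O)c1ccccc1NCC1=NCCN1`: < 6310 nM

Compound 2 is the only one of the three with a number in an assay on CHO cells for binding affinity to Alpha-2B adrenergic receptor (Homo sapiens), read by radioligand binding; a lower number here means a stronger inhibitor, a higher number a weaker inhibitor. In this assay compound 2 gives 331 nM. For compound 1 the assay reports only a limit, < 6310 nM. For compound 3 it likewise reports only a limit, < 6310 nM. The step that the limit leaves unreadable from compound 1 to compound 2 therefore cannot be sized, because of the limit of < 6310 nM in this assay, at which 2 of the 3 values shown sit. Compound 4 `CSc1ccc(Cl)cc1NCC1=NCCN1` differs from compound 2 by chloro in place of fluoro on an aromatic carbon. Within the data shown here, no measured step covers a halogen swap of this kind, so no shift beyond the scatter is expected. Compound 4 is expected to give 250 nM, with a range of 80 nM to 800 nM. The expected step is a 1.3-fold lower number from compound 2 to compound 4 (0.12 log units; within the scatter).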

Compound 4, inhibition constant: 676 nM
Compound 4: the middle estimate sits 2.7-fold (0.43 log units) below what was measured; low and high end bracket the measured number.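

In this assay, among these compounds, this halogen swap is the first change on the shared core that can be sized: a 2.0-fold higher number from compound 2 to compound 4 (0.31 log units; beyond the scatter). The position para to a methylsulfanyl group therefore responds even to a one-atom swap of fluoro for chloro, though only modestly, and fluoro gives the lower number of the two. No measurement shown gives a cause for this step.

From the compounds shown here alone, whether a methoxy or trifluoromethyl group at this position would give a lower number stays open. So does whether chloro in place of fluoro would shift the number with a methylsulfonyl group in place of the methylsulfanyl group.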